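Thiophene for Fluorophenyl on the Sulfonyl of Compound 2

The source may hold more compounds than are shown below. What is called first, only, known or untested is meant among the compounds shown, and "the series" means these compounds.

Of the compounds shown here, two with a shared core have been tested in an assay on HeLa cells for displacement of a labelled ligand from 5-hydroxytryptamine receptor 6 (Homo sapiens); on this read-out higher numbers stand for weaker inhibition and lower numbers for stronger inhibition. Compound 1 `CCn1nc(S(=O)(=O)c2cccc3ccccc23)c2cc(N3CCN(C)CC3)ccc21` gives 1.7 nM in this assay. Compound 2 `CN1CCN(c2ccc3[nH]nc(S(=O)(=O)c4ccc(F)cc4)c3c2)CC1` gives 5.2 nM in this assay, which is the higher of the two numbers, so on this read-out compound 2 is the weaker inhibitor of the pair. Compound 3 `CN1CCN(c2ccc3[nH]nc(S(=O)(=O)c4cccs4)c3c2)CC1` has not yet been measured. It differs from compound 2 in a single place: thiophen-2-yl in place of 4-fluorophenyl on a sulfonyl sulfur. Among the measured compounds shown here, no measured pair so far shows what such an exchange on the sulfonyl sulfur does to this read-out, so the expectation rests on compound 2 alone. Compound 3 is expected to stay close to compound 2, with the step of a 1.0-fold lower number from compound 2 to compound 3 (0.02 log units; within the scatter) expected to fall within the usual scatter, in either direction. The estimate for compound 3 is 5 nM, with a range from 1.5 nM to 15 nM.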

Compound 3, inhibition constant: 7.8 nM
Beside the measured number, compound 3's estimate is 1.6-fold (0.19 log units) below it; the range from low to high includes it.
By their numbers in this assay, from the lowest: compound 1; then compounds 2 and 3 (each within the scatter of the next).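

In this assay, the exchange of 4-fluorophenyl for thiophen-2-yl on the sulfonyl sulfur gives a 1.5-fold higher number from compound 2 to compound 3 (0.18 log units; within the scatter), so the two compounds cannot be told apart on this read-out. This first measured exchange at this place shows that, in this one pair on the shared core, a five-membered aromatic ring with a sulfur atom is tolerated as well as a six-membered carbon ring bearing fluorine. No measurement of any property of these two groups accompanies the result.

The compounds shown leave open whether a saturated ring such as cyclohexyl, a plain chain such as butyl, or a ring carrying an amine would also hold the read-out on the sulfonyl sulfur. They also leave open whether the same exchange would give a similar outcome on the core of compound 1.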